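Fluorinated open chain amine in place of aminocyclohexyl

The source may hold more compounds than are shown below. What is called first, only, known or untested is meant among the compounds shown, and "the series" means these compounds.

Of the compounds shown here, three have been measured in a functional assay on CCRF-CEM cells for antagonist activity at C-X-C chemokine receptor type 4 (Homo sapiens), read by calcium flux, with stated times of 25 min and 90 s; on this read-out lower numbers stand for stronger inhibition and higher numbers for weaker inhibition. Compound 1 `FC1(F)CCC(NC/C=C\CN(C[C@H]2Cc3ccccc3CN2)[C@H]2CCCc3cccnc32)CC1` gives 98 nM and compound 3 `C/C(=C/CN(C[C@H]1Cc2ccccc2CN1)[C@H]1CCCc2cccnc21)CN` gives 8.6 nM. Compound 2 `N[C@H]1CC[C@@H](N(C[C@H]2Cc3ccccc3CN2)[C@H]2CCCc3cccnc32)CC1` gives 1800 nM, the highest number of the three and beyond the scatter from both compound 1 and compound 3. Compound 4 `C/C(CN(C[C@H]1Cc2ccccc2CN1)[C@H]1CCCc2cccnc21)=C(/F)CN` is not yet measured; it differs from compound 2 by 4-amino-3-fluoro-2-methylbut-2-en-1-yl in place of 4-aminocyclohexyl on an amine nitrogen. Within the data shown here, only one measured step bears on this change: a 210-fold lower number from compound 2 to compound 3 (2.32 log units; beyond the scatter). In that step the same ring group left the same amine nitrogen and a chain entered that differs from the chain of compound 4 only in lacking the fluorine. A step of similar size and direction is therefore expected here; whether the added fluorine moves the number further or back cannot be read from these three compounds, which widens the range. The step from compound 2 to compound 4 is estimated as a 120-fold lower number from compound 2 to compound 4 (2.08 log units; beyond the scatter). For compound 4 the expected value in this assay is 15 nM, with a range from 4 nM to 60 nM.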

Compound 4, half-maximal inhibitory concentration: 1800 nM
Compound 4: the middle estimate sits 120-fold (2.08 log units) below what was measured; the whole stated range lies below it.
By their numbers in this assay, from the lowest: compound 3; then compound 1; then compounds 2 and 4 (each within the scatter of the next).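

In this assay, an open chain on the amine nitrogen does not by itself improve on 4-aminocyclohexyl: with 4-amino-3-fluoro-2-methylbut-2-en-1-yl in its place there is no change at the digits printed from compound 2 to compound 4 (within the scatter). The chain of compound 3 behaves very differently, with a 210-fold higher number from compound 3 to compound 4 (2.32 log units; beyond the scatter), which shows that this position responds sharply to small changes within the chain; the structures show that these two chains differ in where the methyl group sits as well as in the fluorine, and the step cannot be assigned to the fluorine alone. Nothing available here accounts for this difference.

Still open, going by these compounds, is which of the two differences carries the step. On these data alone, it is also open whether a 4-aminobut-2-en-1-yl chain, with neither methyl nor fluorine, or a chain with chlorine in place of the fluorine would fall nearer compound 3 or compound 4.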